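Varying the Group on the Sulfur-Linked Chain Carbon

The source may hold more compounds than are shown below. What is called first, only, known or untested is meant among the compounds shown, and "the series" means these compounds.

Compound 1, `Cc1ccc(CSc2nc3nc(C)cc(Nc4cc(-c5ccccc5)[nH]n4)n3n2)cc1`, gives 7310 nM in a functional assay on PC-9 cells (Homo sapiens) for inhibition, read by MTT assay, with a stated time of 72 h; on this read-out lower numbers stand for stronger inhibition and higher numbers for weaker inhibition.
Compound 2, `Cc1cc(Nc2cc(-c3ccccc3)[nH]n2)n2nc(SCc3ccc(Cl)cc3)nc2n1`, gives 6710 nM in this assay.
Compound 3, `Cc1cc(Nc2cc(-c3ccccc3)[nH]n2)n2nc(SCc3cccc4ccccc34)nc2n1`, gives 3950 nM in this assay.

Compound 3 has the lowest of the three numbers, yet its steps from the others, a 1.9-fold lower number from compound 1 to compound 3 (0.27 log units; within the scatter) and a 1.7-fold lower number from compound 2 to compound 3 (0.23 log units; within the scatter), are both within the scatter, so no order among the three can be claimed. Compound 4, `Cc1cc(Nc2cc(-c3ccccc3)[nH]n2)n2nc(SCC(=O)c3ccccc3)nc2n1`, differs from compound 3 by benzoyl in place of naphthalen-1-yl on a saturated chain carbon bound to a sulfur. For the measured compounds named here, the only measured steps that bear on this change are the two that also alter the group on the saturated chain carbon bound to a sulfur, and both stayed within the scatter; the step of a 1.1-fold lower number from compound 1 to compound 2 (0.04 log units; within the scatter) elsewhere on the structure did too. For compound 4 the expected step is therefore a 1.3-fold higher number from compound 3 to compound 4 (0.10 log units; within the scatter), with no direction favoured. Compound 4 is estimated at 5000 nM, expected to lie between 1500 nM and 16000 nM.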

Compound 4, half-maximal inhibitory concentration: 4450 nM
Beside the measured number, compound 4's estimate is 1.1-fold (0.05 log units) above it; low and high end bracket the measured number.
By their numbers in this assay, from the lowest: compounds 3, 4, 2 and 1 (each within the scatter of the next).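

Benzoyl brings a carbonyl with one hydrogen-bond acceptor and a single aromatic ring in place of the two of naphthalen-1-yl, yet in this assay the result is a 1.1-fold higher number from compound 3 to compound 4 (0.05 log units; within the scatter) and, against the single-ring groups, a 1.5-fold lower number from compound 2 to compound 4 (0.18 log units; within the scatter) and a 1.6-fold lower number from compound 1 to compound 4 (0.22 log units; within the scatter). Four different groups on this saturated chain carbon bound to a sulfur now give no step beyond the scatter, even with the added acceptor. Nothing available accounts for this flat picture. As far as these compounds go, what an amine or a carboxylic acid at this place would do remains open, as does whether any group here can move the number beyond the scatter.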